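Isopropyl after ethyl: cytotoxicity of compound 4

The source may hold more compounds than are shown below. What is called first, only, known or untested is meant among the compounds shown, and "the series" means these compounds.

Measured so far in an ADME assay on L929 cells (Mus musculus) for cytotoxicity, read by resazurin assay, with a stated time of 96 h (a lower number here means that less compound is tolerated, a higher number that more compound is tolerated), for the series:
compound 1 `Cc1ccc(/C(COc2ccc(Br)cc2)=N\NC(N)=S)cc1` gives 13200 nM
compound 2 `NC(=S)N/N=C(\COc1ccccc1)c1ccc(Br)cc1` gives 54900 nM
compound 3 `CCc1ccc(OC/C(=N\NC(N)=S)c2ccc(Br)cc2)cc1` gives < 25500 nM

For compound 3 the reading < 25500 nM is a limit of the assay and not a number. Going by the values given here, it is the only such reading (the limit of < 25500 nM in this assay, at which 1 of the 3 values shown sits), so compound 3 has no exact position on the scale.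

The next analogue is compound 4 `CC(C)c1ccc(OC/C(=N\NC(N)=S)c2ccc(Br)cc2)cc1` and the change is methyl in place of hydrogen on a saturated chain carbon bound to an aromatic carbon and a saturated chain carbon (methyl in place of hydrogen on a saturated chain carbon bound to an aromatic carbon and a saturated chain carbon, or ethyl to isopropyl). Among the compounds with values here, one measured step bears on it: an at least 2.1-fold lower number from compound 2 to compound 3 (0.33 log units; beyond the scatter) for ethyl in place of hydrogen on an aromatic carbon. Adding one more carbon to that ethyl is a smaller change, so a modest further fall in this assay is expected, or none beyond the scatter. The expected size is a step that the limit leaves unreadable from compound 3 to compound 4 as an estimate only. For compound 4 the estimated value is 17000 nM with an expected range from 7000 nM to 30000 nM in this assay.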

Compound 4, half-maximal cytotoxic concentration: 24600 nM
Compound 4: middle estimate off by 1.4-fold (0.16 log units), on the low side; the measured number falls inside the stated range.
By their numbers in this assay, from the lowest: compounds 1 and 4 (each within the scatter of the next); then compound 2.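

In this assay, the isopropyl group gives a 2.2-fold lower number from compound 2 to compound 4 (0.35 log units; beyond the scatter), so this position now has a step of readable size for a branched group, which the ethyl of compound 3 could not supply. Ethyl and isopropyl at this position therefore both go with a lower number than the hydrogen of compound 2. The step from ethyl to isopropyl itself cannot be read, since the reading for compound 3 is a limit of the assay: the limit of < 25500 nM in this assay, at which 1 of the 4 values shown sits.

On these data alone, whether adding that methyl changes the number at all remains open. Also open, as far as these compounds go, is whether a longer chain such as butyl, or an amine or a carboxylic acid, at the same position would keep the number on this side of compound 2.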